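From furan-2-yl to phenyl on the amide carbonyl

The source may report more compounds than this note shows. Statements on the series, on what has been measured and on what is new or still open speak of the compounds shown alone.

In a functional assay on NCI-H460 cells (Homo sapiens) for antiproliferative activity (a higher number here means a weaker inhibitor, a lower number a stronger inhibitor), compound 3 (`COc1ccc(S(=O)(=O)Oc2ccccc2NC(=O)c2ccco2)cc1`) gives 24 nM as the lowest number among the measured compounds. Compound 1 (`COc1ccc(S(=O)(=O)Oc2ccccc2NC(=O)c2ccncc2)cc1`) stands nearest with 55 nM as its value. Compound 2 (`COc1ccc(S(=O)(=O)Oc2ccccc2NC(=O)c2ccc(N(C)C)cc2)cc1`) gives > 10000 nM as a limit of the assay and not a number.

Compound 4 (`COc1ccc(S(=O)(=O)Oc2ccccc2NC(=O)c2ccccc2)cc1`) differs from compound 3 in one group, with phenyl in place of furan-2-yl on a carbonyl carbon.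

All three measured steps fall at this same place. The exchange of pyridin-4-yl for furan-2-yl is modest (a 2.3-fold lower number from compound 1 to compound 3 (0.36 log units; beyond the scatter)). The two steps involving 4-(dimethylamino)phenyl are large (an at least 180-fold higher number from compound 1 to compound 2 (2.25 log units; beyond the scatter) and an at least 410-fold lower number from compound 2 to compound 3 (2.61 log units; beyond the scatter)) and both rest on the limit of compound 2. Compound 4 carries phenyl without the dimethylamino group, so it need not follow compound 2 all the way. Compound 2 is still the only measured case with a six-membered ring of carbon only at this place, which leaves the upper side open. A modest to moderate rise in this assay is therefore expected, larger than the step between compound 1 and compound 3 but far short of the steps to compound 2. The expected step is a 3.8-fold higher number from compound 3 to compound 4 (0.57 log units; beyond the scatter) in this estimate. The estimated value of compound 4 is 90 nM with an expected range of 25 nM to 700 nM for this measurement.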

Compound 4, half-maximal inhibitory concentration: 410 nM
For compound 4 the middle estimate is 4.6-fold (0.66 log units) below the measured one; the measured number falls inside the stated range.
By their numbers in this assay, from the lowest: compound 3; then compound 1; then compound 4. At a limit, above all of these: compound 2.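

In this assay, phenyl on the amide carbonyl is clearly poorer than either ring carrying a hetero atom, with a 17-fold higher number from compound 3 to compound 4 (1.23 log units; beyond the scatter) and a 7.5-fold higher number from compound 1 to compound 4 (0.87 log units; beyond the scatter), so a benzamide loses much of the activity even without any added substituent, and ring size alone does not sort the series, since pyridin-4-yl in compound 1 still holds up well. The dimethylamino group adds a further loss on top of that, as hydrogen in its place gives an at least 24-fold lower number from compound 2 to compound 4 (1.38 log units; beyond the scatter), which means the collapse at compound 2 is only partly a matter of the substituent and partly of the carbon-only ring. Compound 2 gives a limit of the assay and not a number, so the true size of that last step stays unknown: the limit of > 10000 nM in this assay, at which 1 of the 4 values shown sits.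

The compounds shown do not separate the presence of a hetero atom from its place in the ring, and thiophen-2-yl or pyridin-3-yl on the same carbonyl carbon would bear on that. From the compounds shown here alone, it also remains open how the phenyl ring responds to substituents other than dimethylamino, such as methoxy or a carboxylic acid, and whether a saturated ring such as cyclohexyl is tolerated here.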